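Chain extension on the aryl ether of compound 1

This account rests on a few compounds, and the source may have more. Where it says the series, first, only, none or still open, it means among the compounds named here.

Measured so far:
compound 1 `N#CCOc1ccc2c(c1)CCc1c-2c2c(c3c4ccccc4n(CCO)c13)CNC2=O`: 8%
compound 2 `COCCOc1ccc2c(c1)CCc1c-2c2c(c3c4ccccc4n(CCO)c13)CNC2=O`: 40%

Going by the values given here, in an assay on isolated protein for inhibition of mitogen-activated protein kinase kinase kinase 11 (Homo sapiens), tested at 1 uM (a higher number here means more inhibition at the concentration tested (going by the name of the read-out), a lower number less inhibition), compound 1 stands lowest of the two numbers known; its nearest neighbour, compound 2, lies a number 32 percentage points higher from compound 1 to compound 2 (beyond the scatter). Compound 3 `N#CCCCOc1ccc2c(c1)CCc1c-2c2c(c3c4ccccc4n(CCO)c13)CNC2=O` has not been measured. It differs from compound 1 in one place: 2-cyanoethyl in place of cyano on a saturated chain carbon bound to an oxygen on an aromatic ring, which reads, cut one bond further out, as cyanomethoxy becoming 3-cyanopropoxy. Among the compounds with values here, no measured step covers this exact change. Within the data shown here, the only step at this position, a number 32 percentage points higher from compound 1 to compound 2 (beyond the scatter), exchanged the cyano group for methoxymethyl rather than lengthening the chain, so it bears on the question only loosely. Among the measured compounds shown here, because compound 1 gives 8% and the one known change at this place moved the number upward, compound 3 is expected to rise modestly, by a number 12 percentage points higher from compound 1 to compound 3 (beyond the scatter). The estimate for compound 3 is 20%, with a range from 3% to 45%.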

Compound 3, a percentage reported as inhibition, at one concentration (the size of the read-out at that concentration, not a potency): 46%
Beside the measured number, compound 3's estimate is 26 percentage points below it; measured number outside the range, above it.
By their numbers in this assay, from the lowest: compound 1; then compounds 2 and 3 (each within the scatter of the next).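

With the nitrile kept, the cyanomethoxy to 3-cyanopropoxy change alone gives, in this assay, a number 38 percentage points higher from compound 1 to compound 3 (beyond the scatter) and so shows that this position responds to the length of the chain, not only to the removal of the nitrile seen with compound 2. Two different chain ends, methoxy and cyanomethyl, then give a number 6 percentage points higher from compound 2 to compound 3 (within the scatter), so across these three compounds the low number belongs to the short cyanomethoxy group of compound 1 rather than to the nitrile as such. No measurement given here explains this difference. Still open, as far as these compounds go, is how a longer chain ending in a nitrile, or a chain ending in an amine or a carboxylic acid, would stand in this assay. Each number also comes from one concentration, which leaves the potency of these compounds open.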